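Cyanomethyl for Acetyl on the Propargylamine Nitrogen

The source may hold more compounds than are shown below. What is called first, only, known or untested is meant among the compounds shown, and "the series" means these compounds.

The series shares one core and differs only at the amine nitrogen that carries the propargyl group. Compound 1 `C#CCN(CCC)Cc1cn(-c2cc(NC(=S)NCC)ncn2)cn1` carries propyl there and gives 24.3% in an assay on isolated protein for inhibition of Amine oxidase [flavin-containing] B (Homo sapiens), read by fluorescence and Amplex Red, with a stated time of 15 min, tested at 50 uM; a higher number here means more inhibition at the concentration tested (going by the name of the read-out), a lower number less inhibition; compound 2 `C#CCN(CCCC)Cc1cn(-c2cc(NC(=S)NCC)ncn2)cn1` carries butyl and gives 20.1%; the step of a number 4.2 percentage points lower from compound 1 to compound 2 (within the scatter) lies within the scatter. Compound 3 `C#CCN(Cc1cn(-c2cc(NC(=S)NCC)ncn2)cn1)C(C)=O` carries acetyl and gives 1.17%, the lowest of the three numbers: the steps of a number 23.1 percentage points lower from compound 1 to compound 3 (beyond the scatter) and a number 18.9 percentage points lower from compound 2 to compound 3 (beyond the scatter) both lie beyond the scatter and are modest in size.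

Compound 4 `C#CCN(CC#N)Cc1cn(-c2cc(NC(=S)NCC)ncn2)cn1` is reached from compound 3 by the change (cyanomethyl in place of acetyl on an amine nitrogen). For the measured compounds named here, the only steps that bear on this position are those from compound 1 and compound 2 to compound 3, where an acetyl group replaced an alkyl chain and inhibition fell by a modest amount. Cyanomethyl returns a saturated chain carbon to the nitrogen, though not an alkyl chain as such, so a modest rise is expected, of the size a number 10.8 percentage points higher from compound 3 to compound 4 (beyond the scatter). Compound 4 is therefore estimated at 12%, with a range from 0% to 30%.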

Compound 4, a percentage reported as inhibition, at one concentration (the size of the read-out at that concentration, not a potency): 15.4%
Compound 4: middle estimate off by 3.4 percentage points, on the low side, and the stated range covers the measured number.
By their numbers in this assay, from the lowest: compound 3; then compounds 4, 2 and 1 (each within the scatter of the next).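

Compound 3's low number does not extend to every replacement of the alkyl chain on this amine nitrogen: in this assay cyanomethyl in place of acetyl gives (a number 14.2 percentage points higher from compound 3 to compound 4 (beyond the scatter)). Cyanomethyl also stands level with the two alkyl chains, as both (a number 4.7 percentage points lower from compound 2 to compound 4 (within the scatter)) and (a number 8.9 percentage points lower from compound 1 to compound 4 (within the scatter)) show, so among these four groups only acetyl stands apart. No measurement here explains why acetyl and cyanomethyl differ, although each of the two groups has the same heavy-atom count.

The compounds shown leave open whether a longer chain ending in a nitrile would stay level with propyl and butyl. They also leave open whether a formyl or methanesulfonyl group on this nitrogen would follow acetyl.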